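Swapping Methyl for Sulfamoyl on a Shared Core

The source may report more compounds than this note shows. Statements on the series, on what has been measured and on what is new or still open speak of the compounds shown alone.

Among three compounds built on one core, compound 3 `Cc1cccc(Nc2nccc(-c3ccccn3)n2)c1` gives 700 nM in a functional assay for inhibition, with Homo sapiens as the target; a lower number here means a stronger inhibitor, a higher number a weaker inhibitor. It stands second highest of the three: compound 2 `CCc1cccc(Nc2nccc(-c3ccccn3)n2)c1` gives 1400 nM, and a 2.0-fold lower number from compound 2 to compound 3 (0.30 log units; within the scatter) lies within the scatter, while compound 1 `Nc1cccc(Nc2nccc(-c3ccccn3)n2)c1` gives 300 nM, a lower number beyond the scatter. Compound 4 `NS(=O)(=O)c1cccc(Nc2nccc(-c3ccccn3)n2)c1` differs from compound 3 in one place: sulfamoyl in place of methyl on an aromatic carbon. For the measured compounds named here, no measured step places a sulfamoyl here, so guidance is indirect. The steps of a 2.3-fold higher number from compound 1 to compound 3 (0.37 log units; beyond the scatter) and a 4.7-fold higher number from compound 1 to compound 2 (0.67 log units; beyond the scatter) show that methyl and ethyl at this place gave higher numbers than amino, so leaving methyl need not hurt. The expected outcome is a small move, a 1.4-fold lower number from compound 3 to compound 4 (0.15 log units; within the scatter). Compound 4 is therefore estimated at 500 nM, with a range from 150 nM to 1800 nM.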

Compound 4, half-maximal inhibitory concentration: 500 nM
Compound 4: the middle estimate sits on the measured number at the digits printed; low and high end bracket the measured number.
By their numbers in this assay, from the lowest: compounds 1, 4, 3 and 2 (each within the scatter of the next, the first and the last beyond it).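

For the compounds shown here, this position takes a much larger group than the earlier compounds showed: sulfamoyl, with 4 heavy atoms, stays within the scatter of methyl (a 1.4-fold lower number from compound 3 to compound 4 (0.15 log units; within the scatter)) and of amino (a 1.7-fold higher number from compound 1 to compound 4 (0.22 log units; within the scatter)). Only against ethyl does the change stand clear of the scatter (a 2.8-fold lower number from compound 2 to compound 4 (0.45 log units; beyond the scatter)). Nothing available explains this result. Still open, as far as these compounds go, is whether a carboxylic acid or an amide at this place would behave like sulfamoyl, and whether a longer chain would push the number higher than ethyl does.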